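A few compounds are considered here, and "the series" means these few. Any claim that something is new, unique, unknown or untested is made for them only; others in the source may bear on it.

Compound 1 `N#CCn1c(=N)sc2cc(OC(F)(F)F)ccc21`: 3.5 mg/kg
Compound 2 `CN(C)S(=O)(=O)CCn1c(=N)sc2cc(OC(F)(F)F)ccc21`: > 10 mg/kg

In a functional assay on the whole organism with Rattus norvegicus as the target (a lower number here means that less compound is needed, a higher number that more compound is needed for the effect), compound 2 stands at > 10 mg/kg, which is a limit and not a number. Compound 3 `CSCCn1c(=N)sc2cc(OC(F)(F)F)ccc21` carries methylsulfanyl in place of dimethylsulfamoyl on a saturated chain carbon, two bonds along the chain from an aromatic nitrogen. For the measured compounds named here, only one measured step bears on this change, an at least 2.8-fold higher number from compound 1 to compound 2 (0.45 log units; beyond the scatter), and that step brought dimethylsulfamoyl onto the chain. With that group gone, a modest move towards a lower number is expected in this assay, and the expected step is an at least 1.6-fold lower number from compound 2 to compound 3 (0.22 log units; that floor lies within the scatter). For compound 3 the estimate is 6 mg/kg, with an expected range from 2 mg/kg to 20 mg/kg.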

Compound 3, dose for half-maximal effect: 1 mg/kg
For compound 3 the middle estimate is 6.0-fold (0.78 log units) above the measured one, outside the stated range (below it).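

In this assay, methylsulfanyl on the saturated chain carbon, two bonds along the chain from an aromatic nitrogen, does more than shed the penalty seen with dimethylsulfamoyl: it gives an at least 10-fold lower number from compound 2 to compound 3 (1.00 log units; beyond the scatter). It also passes the cyano compound, with a 3.5-fold lower number from compound 1 to compound 3 (0.54 log units; beyond the scatter), so this chain can move the number down as well as up. The first of these steps is only a floor, because compound 2 rests at a limit and not a number: the limit of > 10 mg/kg in this assay, at which 1 of the 3 values shown sits.

What the compounds shown leave open is whether the sulfur of methylsulfanyl is needed, as a methoxy group in its place would tell, and how a longer chain would read in this assay.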